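The source may report more compounds than this note shows. Statements on the series, on what has been measured and on what is new or still open speak of the compounds shown alone.

The two measured compounds share a core built around a dienone linker and a coumarin-bearing triazole side chain. Compound 1 `COc1cc(/C=C/C(=O)/C=C/c2cc(OC)c(OC)c(OC)c2)ccc1OCc1cn(CCOc2cc(=O)oc3ccccc23)nn1` gives 86% in a functional assay on COLO 205 cells (Homo sapiens) for inhibition, read by sulforhodamine B assay, with a stated time of 48 h, tested at 50 uM; on this read-out lower numbers stand for less inhibition of growth and higher numbers for more inhibition of growth at the one concentration tested. Among the compounds with values here, compound 2 `COc1ccccc1/C=C/C(=O)/C=C/c1ccc(OCc2cn(CCCCOc3cc(=O)oc4ccccc34)nn2)c(OC)c1` gives 47% in this assay, the lowest of the two numbers; the only neighbour is compound 1, whose number lies higher by an amount beyond the scatter. Within the data shown here, no single-change step between measured compounds is available, so the size of the move from compound 2 to compound 3 cannot be read from a precedent. Compound 3 `COc1cc(/C=C/C(=O)/C=C/c2ccco2)ccc1OCc1cn(CCCCOc2cc(=O)oc3ccccc23)nn1` differs from compound 2 by one change (furan-2-yl in place of 2-methoxyphenyl on a double-bonded chain carbon bound to a double-bonded chain carbon). The two measured numbers tell only that the aryl terminus matters, not how a five-membered aromatic ring with one hetero atom would shift the read-out. Compound 3 is therefore expected to land with a step of a number 3 percentage points higher from compound 2 to compound 3 (within the scatter), a move that is not expected to go beyond the scatter in either direction. Compound 3 is estimated at 50% in this assay, within a range from 25% to 75%.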

Compound 3, percent growth inhibition at one concentration: 43%
Estimate against measurement, compound 3: 7 percentage points above, within the range that was stated.
By their numbers in this assay, from the lowest: compounds 3 and 2 (each within the scatter of the next); then compound 1.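

In this assay, putting furan-2-yl in place of 2-methoxyphenyl on a double-bonded chain carbon bound to a double-bonded chain carbon gives a number 4 percentage points lower from compound 2 to compound 3 (within the scatter). Within the data shown here, this is the first single-change step available at this position, and it shows that a five-membered aromatic ring with one hetero atom and a six-membered aromatic ring of carbon only cannot be told apart here, even though the entering group has 5 heavy atoms and the leaving group 8. Nothing measured bears on why the two groups read alike.

As far as these compounds go, compound 1 differs from compound 2 and compound 3 in more than one place, so the steps to it cannot be read, and the share of any one of its differences in its number stays unknown. The compounds shown also leave open whether a group of a different kind at this position, such as a carboxylic acid, a dimethylamino group or a plain methyl group, would move the number beyond the scatter.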